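The compounds below may be only part of what the source reports. "The series", "measured", "known", "first", "only" and "open" are said of these compounds alone.

Compound 3 `NC(=O)c1ccc(-c2cc(Nc3ccc(OC(F)(F)F)cc3)ncn2)cc1` is known only by a limit: in an ADME assay on BaF3 cells (Mus musculus) for cytotoxicity (a higher number here means that more compound is needed for the effect, a lower number that less compound is needed), compound 3 gives > 10000 nM. Compound 1 `Nc1cccc(-c2cc(Nc3ccc(OC(F)(F)F)cc3)ncn2)c1` also reaches only a limit, giving > 10000 nM in this assay. Compound 2 `COc1ccc(Nc2cc(-c3ccncc3)ncn2)cc1` likewise stops at a limit of > 10000 nM in this assay. Going by the values given here, the single measured step, a step that the two limits leave unreadable from compound 1 to compound 3, cannot be read because of the limit of > 10000 nM in this assay, at which 3 of the 3 values shown sit. Compound 4 `FC(F)(F)Oc1ccc(Nc2cc(-c3ccncc3)ncn2)cc1` differs from compound 3 by pyridin-4-yl in place of 4-carbamoylphenyl on an aromatic carbon. Among the compounds with values here, no measured step bears on this change in a readable way, and every value so far sits at the same limit, so no step beyond the scatter is expected in this assay. Compound 4 is therefore expected to sit at 15000 nM, between 6000 nM and 40000 nM, which would be a step that the limit leaves unreadable from compound 3 to compound 4.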

Compound 4, half-maximal effective concentration: > 10000 nM
Compound 4 ended at the assay's limit; the forecaster's own chance of this, stated with the estimate: 80%; the middle value lies beyond the limit too.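

Compound 4 also stops at a limit, so its steps from compound 1, compound 2 and compound 3 cannot be read: the limit of > 10000 nM in this assay, at which 4 of the 4 values shown sit.

The compounds shown leave open how these four truly compare in this assay, and which change, if any, would bring a value under that limit.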